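Halophenyl swap on the aryl amine: bromo returns with fluoro

The compounds below may be only part of what the source reports. "The series", "measured", "known", "first", "only" and "open" are said of these compounds alone.

Compound 3 `Cc1n[nH]c2ccc(-c3nc4cnc(N5CCN(C)CC5)cn4c3Nc3ccc(I)cc3)cc12` gives 0% in a functional assay on MV4-11 cells (Homo sapiens) for inhibition, with a stated time of 120 h, tested at 10 uM (a higher number here means more inhibition at the concentration tested (going by the name of the read-out), a lower number less inhibition), and stands lowest of the three numbers measured. Its nearest neighbour is compound 1 `Cc1n[nH]c2ccc(-c3nc4cnc(N5CCC(C)CC5)cn4c3Nc3ccc(Cl)cc3)cc12`, which differs from it in more than one place and gives 28%; furthest is compound 2 `Cc1n[nH]c2ccc(-c3nc4cnc(N5CCN(C)CC5)cn4c3Nc3ccc(Br)cc3)cc12` with 83%. Going by the values given here, the one single-point step measured so far is a number 83 percentage points lower from compound 2 to compound 3 (beyond the scatter), so a bromo on the aryl ring sits on the high side and an iodo on the low side.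

Compound 4 `Cc1n[nH]c2ccc(-c3nc4cnc(N5CCN(C)CC5)cn4c3Nc3ccc(F)cc3Br)cc12` carries 2-bromo-4-fluorophenyl in place of 4-iodophenyl on a nitrogen on an aromatic ring. Among the compounds with values here, no measured pair isolates the added fluorine, and the bromo here sits in a different named position than in compound 2, so that step is only a partial guide. Still, since the iodo leaves and a bromo enters, a rise from compound 3 is expected, of roughly a number 45 percentage points higher from compound 3 to compound 4 (beyond the scatter), though with wide uncertainty. Compound 4 is therefore estimated at 45%, within a range of 5% to 85%.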

Compound 4, a percentage reported as inhibition, at one concentration (the size of the read-out at that concentration, not a potency): 82.4%
Estimate against measurement, compound 4: 37.4 percentage points below, within the range that was stated.
By their numbers in this assay, from the lowest: compound 3; then compound 1; then compounds 4 and 2 (each within the scatter of the next).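

On the aryl group at the amine nitrogen, this assay shows a number 82.4 percentage points higher from compound 3 to compound 4 (beyond the scatter), while a number 0.6 percentage points lower from compound 2 to compound 4 (within the scatter) leaves 2-bromo-4-fluorophenyl and 4-bromophenyl indistinguishable. Among the three aryl groups on the shared core with the methylpiperazine, the low number therefore stays with 4-iodophenyl, and both bromine-bearing rings read high, so this position accepts more than one bromine-bearing pattern. The data offered here contain no evidence that accounts for the sharp split between these aryl groups.

Still open, on these data alone, is how much of the reading of compound 4 belongs to the bromine and how much to the fluorine, which a phenyl carrying only one of them would separate. Equally open, as far as these compounds go, is how a methoxy group or a nitrile, rather than a halogen, would read on this ring.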